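Replacing the methoxyphenyl in a compound already at the limit

The source may report more compounds than this note shows. Statements on the series, on what has been measured and on what is new or still open speak of the compounds shown alone.

Three compounds have been measured in a functional assay on PC-3 cells (Homo sapiens) for cytotoxicity, read by MTT assay, with a stated time of 72 h; on this read-out lower numbers stand for stronger inhibition and higher numbers for weaker inhibition:
Compound 1, `COc1ccc(Nc2nc3ccccc3nc2S(=O)(=O)c2ccccc2)cc1`, gives 1510 nM.
Compound 2, `Nc1ccc(Nc2nc3ccccc3nc2S(=O)(=O)c2ccccc2)cc1`, gives 5830 nM.
Compound 3, `COc1ccc(Nc2nc3ccccc3nc2S(=O)(=O)c2ccc(C)cc2)cc1`, gives only a limit of the assay, not a number: > 50000 nM.

Compound 3 thus stands at the limit of > 50000 nM in this assay, at which 1 of the 3 values shown sits, the weakest point the assay can report, and its true value may lie anywhere beyond it.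

Compound 4, `Cc1ccc(S(=O)(=O)c2nc3ccccc3nc2Nc2cccc(O)c2)cc1`, keeps the methyl-bearing sulfonyl ring of compound 3 and alters the other ring: 3-hydroxyphenyl in place of 4-methoxyphenyl on a nitrogen on an aromatic ring.

Among the compounds with values here, no measured step matches this change exactly. The closest is a 3.9-fold higher number from compound 1 to compound 2 (0.59 log units; beyond the scatter), where swapping the group on that same aniline ring raised the number modestly. The step of an at least 33-fold higher number from compound 1 to compound 3 (1.51 log units; beyond the scatter) shows that the methyl already present in compound 3 and compound 4 carries a large loss on its own. Compound 4 is therefore expected to remain at or beyond the limit in this assay, with the step that the limit leaves unreadable from compound 3 to compound 4 estimated as no improvement beyond the scatter. Compound 4 is expected to give about 80000 nM, with a range from 20000 nM to 300000 nM, and most likely the assay will again report only a limit.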

Compound 4, half-maximal inhibitory concentration: 1690 nM
For compound 4 the middle estimate is 47-fold (1.68 log units) above the measured one, and the stated range ends above it.
By their numbers in this assay, from the lowest: compounds 1 and 4 (each within the scatter of the next); then compound 2. At a limit, above all of these: compound 3.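

In this assay, within the data shown here, exchanging 4-methoxyphenyl for 3-hydroxyphenyl on the nitrogen gives an at least 29-fold lower number from compound 3 to compound 4 (1.47 log units; beyond the scatter), whereas the only earlier change on this ring, a 3.9-fold higher number from compound 1 to compound 2 (0.59 log units; beyond the scatter), was modest, so this place can matter far more than that first step suggested. The methyl on the sulfonyl ring therefore does not rule out a readable value on its own: compound 4 carries the same methyl and gives 1690 nM. The true size of the new step remains unknown, because compound 3 gives a limit and not a number: the limit of > 50000 nM in this assay, at which 1 of the 4 values shown sits.

The exchange alters two things at once, the group on the ring and where it sits, so the compounds shown cannot say whether the hydroxy group, its place on the ring, or both together account for the gain. They also leave open what removing the methyl from compound 4 would do, and how a larger group on the same ring, such as a carboxylic acid or a longer ether chain, would fare in this assay.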